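The source may report more compounds than this note shows. Statements on the series, on what has been measured and on what is new or still open speak of the compounds shown alone.

Measured so far in a functional assay on HCT-116 cells (Homo sapiens) for antiproliferative activity, read by MTT assay, with a stated time of 72 h; a lower number here means a stronger inhibitor, a higher number a weaker inhibitor:
- Compound 1 `O=C(NO)c1ccc(NCCOc2ccc3cc2COC/C=C/COCc2cccc(c2)-c2ccnc(n2)N3)cc1`: 3200 nM
- Compound 2 `O=C(O)CCCCCOc1ccc2cc1COC/C=C/COCc1cccc(c1)-c1ccnc(n1)N2`: 41000 nM
- Compound 3 `O=C(O)c1cccc(NCCOc2ccc3cc2COC/C=C/COCc2cccc(c2)-c2ccnc(n2)N3)c1`: 59200 nM

Compound 3, at 59200 nM, stands level with compound 2, the other compound ending in a carboxy group: the data show a 1.4-fold higher number from compound 2 to compound 3 (0.16 log units; within the scatter). Compound 1 ends in a hydroxycarbamoyl group instead, and both carboxy compounds lie far from it, with a 13-fold higher number from compound 1 to compound 2 (1.11 log units; beyond the scatter) and a 19-fold higher number from compound 1 to compound 3 (1.27 log units; beyond the scatter).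

Compound 4 `O=C(NO)c1cccc(NCCOc2ccc3cc2COC/C=C/COCc2cccc(c2)-c2ccnc(n2)N3)c1` keeps all of compound 3 except for one small change: hydroxyamino in place of hydroxy on a carbonyl carbon. Hydroxyamino replaces hydroxy on a carbonyl carbon, so 3-carboxyphenyl becomes 3-(hydroxycarbamoyl)phenyl.

The best guide is a 19-fold higher number from compound 1 to compound 3 (1.27 log units; beyond the scatter), read in reverse, but it is not a clean comparison. That step swaps 4-(hydroxycarbamoyl)phenyl for 3-carboxyphenyl, so it changes the position of the group as well as the group itself. Within the data shown here, no measured compound separates these two parts of the change. A large move towards a lower number is still the likeliest outcome, perhaps slightly smaller than the guide step.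

The expected step in this assay is a 12-fold lower number from compound 3 to compound 4 (1.07 log units; beyond the scatter), which would lie beyond the scatter. The estimated value for compound 4 is 5000 nM, with an expected range from 1500 nM to 16000 nM.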

Compound 4, half-maximal inhibitory concentration: 2010 nM
Beside the measured number, compound 4's estimate is 2.5-fold (0.40 log units) above it; the measured number falls inside the stated range.
By their numbers in this assay, from the lowest: compounds 4 and 1 (each within the scatter of the next); then compounds 2 and 3 (each within the scatter of the next).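

In this assay, the swap of hydroxyamino for hydroxy on a carbonyl carbon gives a 29-fold lower number from compound 3 to compound 4 (1.47 log units; beyond the scatter) with nothing else altered, so this change alone can account for a large shift, something the earlier steps could not separate from a move of the group around the ring. The ring position itself can now be read too: a 1.6-fold lower number from compound 1 to compound 4 (0.20 log units; within the scatter) when 3-(hydroxycarbamoyl)phenyl stands in place of 4-(hydroxycarbamoyl)phenyl, so among these compounds the position of the group makes no difference beyond the scatter, while the carbonyl end group does. The step of a 20-fold lower number from compound 2 to compound 4 (1.31 log units; beyond the scatter) fits the same picture, though it also replaces the 3-carboxypropyl chain, and all four compounds now fall into two groups, with both hydroxycarbamoyl compounds at the lower numbers and both carboxy compounds at the higher ones.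

Nothing given here offers a measured reason for the size of these steps. Going by these compounds, it also remains open whether a methyl ester or a primary amide on the same carbonyl carbon would sit with the carboxy or the hydroxycarbamoyl compounds, and whether a hydroxycarbamoyl group on the saturated chain of compound 2 would bring a similar drop.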